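Replacing the Aryl Sulfonamide with a Benzyl Sulfonamide

The compounds below may be only part of what the source reports. "The series", "measured", "known", "first", "only" and "open" are said of these compounds alone.

In a functional assay (plasma) for inhibition, with Oryctolagus cuniculus as the target (on this read-out higher numbers stand for weaker inhibition and lower numbers for stronger inhibition), compound 3 `O=C(O)CCC/C=C\C[C@H]1[C@@H]2CCC(C2)[C@@H]1NS(=O)(=O)c1ccc(Cl)cc1` gives 300 nM, the lowest of the two single numbers shown. Its nearest neighbour is compound 1 `CCc1ccc(S(=O)(=O)N[C@H]2C3CC[C@H](C3)[C@@H]2C/C=C\CCCC(=O)O)cc1`, which gives 4600 nM, so that a 15-fold lower number from compound 1 to compound 3 (1.19 log units; beyond the scatter). Compound 2 `O=C(O)CCC/C=C\C[C@H]1[C@@H]2CCC(C2)[C@@H]1NS(=O)(=O)c1ccccc1` gives 1000 nM; 7400 nM; 600 nM (3 entries) over its repeats, and these several entries the several entries of compound 2 in this assay, 1000 nM; 7400 nM; 600 nM (3 entries) show how widely a single compound can read in this assay. Compound 4 `O=C(O)CCC/C=C\C[C@H]1[C@@H]2CCC(C2)[C@@H]1NS(=O)(=O)Cc1ccccc1` differs from compound 3 by benzyl in place of 4-chlorophenyl on a sulfonyl sulfur. Among the compounds with values here, no measured step alters the group on the sulfonyl sulfur itself; the only measured step exchanges one substituent of an aromatic ring for another. Compound 4 is expected to give back much of the gain of compound 3, a 10-fold higher number from compound 3 to compound 4 (1.00 log units; beyond the scatter). Compound 4 is therefore estimated at 3000 nM, with a range from 800 nM to 12000 nM.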

Compound 4, half-maximal inhibitory concentration: 113000 nM
Compound 4: the middle estimate sits 38-fold (1.58 log units) below what was measured; measured number above the stated range.
By their numbers in this assay, from the lowest: compound 3; then compound 1; then compound 4.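

In this assay, the earlier step exchanged only one substituent of an aromatic ring, whereas this change alters the group on the sulfonyl sulfur itself and costs far more: a 380-fold higher number from compound 3 to compound 4 (2.58 log units; beyond the scatter). The same exchange starting from 4-ethylphenyl gives a 25-fold higher number from compound 1 to compound 4 (1.39 log units; beyond the scatter), so benzyl reads well above both aryl groups compared with it. The repeats of a single compound spread widely, yet all of them stay far short of the number for compound 4: the several entries of compound 2 in this assay, 1000 nM; 7400 nM; 600 nM (3 entries)

The compounds shown leave open whether 4-chlorobenzyl or a longer chain such as phenethyl on the sulfonyl sulfur would read differently from benzyl. They also cannot tell why benzyl reads so high.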